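From Compound 2 to Compound 4: A Second Fluorine

The source may hold more compounds than are shown below. What is called first, only, known or untested is meant among the compounds shown, and "the series" means these compounds.

Three sulfonamides have been measured so far in a physicochemical assay for lipophilicity, at pH 7.4 (on this read-out lower numbers stand for lower lipophilicity and higher numbers for higher lipophilicity), on a scale where the numbers span a wide range. Compound 1 (`CCc1ccc(N(CC(C)C)S(=O)(=O)c2ccc3cc(OCC4CCOCC4)c(C(=O)O)cc3c2)cc1`) reads 1.77 while compound 2 (`CC(C)CN(c1cccc(F)c1)S(=O)(=O)c1ccc2c(c1)C(=O)CC(C1CCOCC1)O2`) reads 3.5 and compound 3 (`CCc1ccc(N(CC(C)C)S(=O)(=O)c2ccc3c(c2)C(=O)CC(C(C)C2CCOCC2)O3)cc1`) reads 4.93 in the same test. Compound 2 therefore stands second highest of the three, with compound 3 nearest above it and compound 1 furthest below, and both gaps lie beyond the scatter.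

Compound 4 (`CC(C)CN(c1ccc(F)cc1F)S(=O)(=O)c1ccc2c(c1)C(=O)CC(C1CCOCC1)O2`) has not yet been measured. It departs from compound 2 in one place, where 2,4-difluorophenyl stands in place of 3-fluorophenyl on a sulfonamide nitrogen (2,4-difluorophenyl in place of 3-fluorophenyl on a sulfonamide nitrogen). Among the measured compounds shown here, no two measured compounds differ in one place only, so the data offer no direct guide to this swap. The expectation therefore starts from compound 2 at 3.5 as its reference point. In this assay the estimated step of a number 0.10 log units higher from compound 2 to compound 4 (within the scatter) is small and upward, and it is expected to stay within the scatter. Compound 4 is expected at 3.6 with an estimated range of 3.2 to 4 in this test.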

Compound 4, distribution coefficient: 3.62
Compound 4: middle estimate off by 0.02 log units, on the low side; measured number inside the range.
By their numbers in this assay, from the lowest: compound 1; then compounds 2 and 4 (each within the scatter of the next); then compound 3.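

In this assay, 2,4-difluorophenyl in place of 3-fluorophenyl on a sulfonamide nitrogen gives a number 0.12 log units higher from compound 2 to compound 4 (within the scatter), so the swap cannot be told apart from repeat measurement. Among the compounds shown here, this is the first step that can be read in one place, since the earlier compounds offered no such pair, and it shows that this position carried a second fluorine on the aromatic ring without a step beyond the scatter. Nothing measured here bears on what lies behind this result.

From the compounds shown here alone, whether a different group on that ring, such as an amine or a nitrile, would give a step beyond the scatter remains open. Going by these compounds, it is also open whether the same swap would read alike on the core of compound 1, which carries other groups elsewhere.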